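The source may hold more compounds than are shown below. What is called first, only, known or untested is meant among the compounds shown, and "the series" means these compounds.

- Compound 1 `COc1cc(OC)c(C(=O)/C=C/c2cccc(Cl)c2)c(O)c1CC=C(C)C` gives 59500 nM
- Compound 2 `COc1ccc(/C=C/C(=O)c2c(OC)cc(OC)c(CC=C(C)C)c2O)cc1` gives 46900 nM
- Compound 3 `COc1cc(OC)c(C(=O)/C=C/c2ccc(N(C)C)cc2)c(O)c1CC=C(C)C` gives > 100000 nM as a limit of the assay, not a number

Going by the values given here, in an ADME assay on MCF7-DOX cells (Homo sapiens) for cytotoxicity, read by MTT assay, with a stated time of 48 h (on this read-out lower numbers stand for stronger inhibition and higher numbers for weaker inhibition), compound 1 stands level with compound 2, the only other number, and the gap is a 1.3-fold lower number from compound 1 to compound 2 (0.10 log units; within the scatter). Compound 3 reports only a limit: the limit of > 100000 nM in this assay, at which 1 of the 3 values shown sits.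

Compound 4 `COc1cc(OC)c(C(=O)/C=C/c2cccc(N3CCN(C)CC3)c2)c(O)c1CC=C(C)C` carries 4-methylpiperazin-1-yl in place of chloro on an aromatic carbon, meta to a large group, and the change counts as 4-methylpiperazin-1-yl in place of chloro on an aromatic carbon. The measured steps that bear on it all exchange the group on the aromatic ring of the chain. The closest case is compound 3, which also brings in a nitrogen group: an at least 1.6-fold higher number from compound 1 to compound 3 (0.22 log units; that floor lies within the scatter) has a floor within the scatter, while an at least 2.1-fold higher number from compound 2 to compound 3 (0.32 log units; beyond the scatter) goes modestly beyond it. On this evidence, no step beyond the scatter is expected in this assay, although a rise to the limit remains possible. The estimated step is a 1.1-fold lower number from compound 1 to compound 4 (0.03 log units; within the scatter). For compound 4 the estimated value is 55000 nM, with an expected range from 18000 nM to 100000 nM.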

Compound 4, half-maximal inhibitory concentration: > 100000 nM
Compound 4: only a limit was reported (the forecaster's own chance of this, stated with the estimate: 25%); at least 1.8-fold (0.25 log units) between middle value and limit.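

In this assay compound 4 gives only a limit of the assay, > 100000 nM, so the 4-methylpiperazin-1-yl group on this aromatic carbon, meta to a large group, yields no number to set against the chloro of compound 1. Read as a step, the exchange is an at least 1.6-fold higher number from compound 1 to compound 4 (0.22 log units; that floor lies within the scatter), which separates the two compounds only by a floor and leaves the true size of the change unknown. What is new is that a second nitrogen-bearing group, here at a different place on the ring from the one in compound 3, also ends at the limit: the limit of > 100000 nM in this assay, at which 2 of the 4 values shown sit.

The compounds shown leave open whether a morpholine or a simple amino group at this position would give a number under the limit. They also leave open whether a carboxylic acid there would read any differently from the chloro of compound 1.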